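Furan to pyrrole on the shared core

This account rests on a few compounds, and the source may have more. Where it says the series, first, only, none or still open, it means among the compounds named here.

Measured in a functional assay on 786-0 cells (Homo sapiens) for inhibition, read by sulforhodamine B assay, with a stated time of 48 h (on this read-out lower numbers stand for stronger inhibition of growth and higher numbers for weaker inhibition of growth), so far:
- compound 1 `CC1=CC[C@H](C(C)(C)NC(=S)NN)CC1`: > 100000 nM
- compound 2 `CC1=CC[C@H](C(C)(C)NC(=S)N/N=C/c2ccccc2Cl)CC1`: > 100000 nM
- compound 3 `CC1=CC[C@H](C(C)(C)NC(=S)N/N=C/c2ccco2)CC1`: 9800 nM

Compound 1 reaches only a limit of this assay with > 100000 nM. Compound 2 likewise gives a limit, > 100000 nM. Going by the values given here, compound 3 is the one member of the series with an actual number, 9800 nM in this assay, and therefore the reference point for what follows.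

Two measured steps lead into compound 3: an at least 10-fold lower number from compound 1 to compound 3 (1.00 log units; beyond the scatter) and an at least 10-fold lower number from compound 2 to compound 3 (1.00 log units; beyond the scatter). Both start from the limit of > 100000 nM in this assay, at which 2 of the 3 values shown sit, so each is known only as a lower bound on its size. Together they show that the group on the carbon with a double bond to nitrogen decides whether growth inhibition is seen at all, and that of the two aromatic groups tried only furan-2-yl gives a number.

Compound 4 `CC1=CC[C@H](C(C)(C)NC(=S)N/N=C/c2ccc[nH]2)CC1` is the next variation: 1H-pyrrol-2-yl in place of furan-2-yl on a carbon with a double bond to nitrogen. Among the compounds with values here, no measured pair swaps one five-membered heteroaryl for another, so neither step above fixes the size of this change; the nearest comparison, from compound 2 to compound 3, says only that the choice of aryl can matter strongly. For compound 4 a step within or near the scatter is expected, a 1.2-fold higher number from compound 3 to compound 4 (0.09 log units; within the scatter). The estimate for compound 4 in this assay is 12000 nM, with a range from 4000 nM to 40000 nM.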

Compound 4, concentration for total growth inhibition: > 100000 nM
Compound 4 gave a limit, no number; the forecaster's own chance of this, stated with the estimate: 30%; middle value at least 8.3-fold (0.92 log units) away from the limit.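

At this position, on a carbon with a double bond to nitrogen, exchanging furan-2-yl for 1H-pyrrol-2-yl is not a neutral swap in this assay: the result is an at least 10-fold higher number from compound 3 to compound 4 (1.00 log units; beyond the scatter), a lower bound on the size of the step. The two groups are both five-membered aromatic rings with the same number of heavy atoms, yet a hydrogen-bond acceptor leaves and a hydrogen-bond donor enters, so a five-membered aromatic ring alone does not secure a number in this series. Compound 3 remains the only member with a number, and the steps to compound 4 from compound 1 and from compound 2 cannot be read, since both ends of each are limits: the limit of > 100000 nM in this assay, at which 3 of the 4 values shown sit.

The compounds shown leave open whether the result for compound 3 depends on the ring oxygen or on the lack of a ring hydrogen on nitrogen; thiophen-2-yl and 1-methyl-1H-pyrrol-2-yl on the same carbon would separate the two. Also open, on these data alone, is what an unsubstituted phenyl or a pyridin-2-yl would give in this assay.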